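The source may hold more compounds than are shown below. What is called first, only, known or untested is meant among the compounds shown, and "the series" means these compounds.

Working notes on the series. Measured so far are compound 1 `COc1cc(N(C)CCN(C)C)c(NC(=O)c2ccncc2)cc1Nc1nccc(-c2cn(C)c3ccccc23)n1`, compound 2 `COc1cc(N(C)CCN(C)C)c(NC(=O)c2ccncc2OC)cc1Nc1nccc(-c2cn(C)c3ccccc23)n1` and compound 3 `COc1ccc(C(=O)Nc2cc(Nc3nccc(-c4cn(C)c5ccccc45)n3)c(OC)cc2N(C)C)nc1`; compound 4 `COc1cc(N(C)C)c(NC(=O)c2ccccn2)cc1Nc1nccc(-c2cn(C)c3ccccc23)n1` is not yet measured. In a functional assay on A549 cells (Homo sapiens) for antiproliferative activity, read by MTT assay, with a stated time of 72 h (a higher number here means a weaker inhibitor, a lower number a stronger inhibitor), compound 1 gives 10400 nM. In this assay compound 2 gives 2690 nM, and compound 3 gives 5150 nM.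

One single-point change is measured. From compound 2 to compound 1 the change is hydrogen in place of methoxy on an aromatic carbon and it produces a 3.9-fold higher number from compound 2 to compound 1 (0.59 log units; beyond the scatter). How the core of compound 3 differs from that of compound 2 is not broken down here; the values of compound 3 and compound 2 lie within the scatter of each other. Compound 1 shows a higher number than compound 3.

Compound 4 arises from compound 3 by hydrogen in place of methoxy on an aromatic carbon. This is the same kind of change as that from compound 2 to compound 1, but not the same: in the earlier pair the carbon is ortho to a large group, in the new pair it is para to a large group. The step from compound 2 to compound 1, a 3.9-fold higher number from compound 2 to compound 1 (0.59 log units; beyond the scatter), points to a higher number once the methoxy is gone; allowing for the different place, for compound 4 a somewhat smaller step is expected, a 1.9-fold higher number from compound 3 to compound 4 (0.29 log units; within the scatter). For compound 4 in this assay the estimate is 10000 nM, expected to fall between 3500 nM and 28000 nM. The estimate rests on a single measured instance of this kind of change, so its range is kept wide.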

Compound 4, half-maximal inhibitory concentration: 8290 nM
Compound 4: the middle estimate sits 1.2-fold (0.08 log units) above what was measured; measured number inside the range.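

In this assay the swap of methoxy for hydrogen on an aromatic carbon gives a 1.6-fold higher number from compound 3 to compound 4 (0.21 log units; within the scatter) and so, on the core of compound 3, leaves no effect clear of the scatter. Set beside the earlier instance of the change, the new step cannot be told apart from it in size: the same change on two cores in this assay, a 3.9-fold higher number (0.59 log units; beyond the scatter) from compound 2 to compound 1 and a 1.6-fold higher number (0.21 log units; within the scatter) from compound 3 to compound 4, 2.4-fold (0.38 log units) apart, within the scatter of two such steps. Among these compounds, this shows that the two results are compatible with one another, but it does not show that the change carries from core to core with a fixed size, nor that its size depends on the core, as only two pairs are at hand and the step lies beyond the scatter in one and within it in the other.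

The compounds shown carry only methoxy or hydrogen at these aromatic carbons, so how a fluorine, an amine or a longer chain such as ethoxy would read there remains open. Also open, as far as these compounds go, is whether the 5-methoxypyridin-2-yl to pyridin-2-yl change would give a similar step on a third core.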